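Swapping the aryl group on the carbonyl of a quinoline chalcone

The compounds below may be only part of what the source reports. "The series", "measured", "known", "first", "only" and "open" are said of these compounds alone.

Measured so far:
- compound 1 `COc1ccc(-c2cc3ccccc3nc2/C=C/C(=O)c2ccc(F)cc2)cc1`: 8320 nM
- compound 2 `COc1ccc(-c2cc3ccccc3nc2/C=C/C(=O)c2ccc(OC)cc2OC)cc1`: 7990 nM

Both compounds share a common core and differ only in the aryl group attached to the carbonyl carbon. In a functional assay on A549 cells (Homo sapiens) for antiproliferative activity, read by XTT assay, with a stated time of 72 h (a lower number here means a stronger inhibitor, a higher number a weaker inhibitor), compound 1 gives 8320 nM and compound 2 gives 7990 nM. Among the measured compounds shown here, the one step measured so far, a 1.0-fold lower number from compound 1 to compound 2 (0.02 log units; within the scatter), shows that exchanging one aryl group for another at this position left the number essentially unchanged. Compound 2 has the lowest of the two numbers, but its gap to compound 1 lies within the scatter, so neither can be called the stronger inhibitor.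

Compound 3 `COc1ccc(-c2cc3ccccc3nc2/C=C/C(=O)c2ccc(N)cc2)cc1` carries the change (4-aminophenyl in place of 2,4-dimethoxyphenyl on a carbonyl carbon). For the measured compounds named here, the only step that bears on it, a 1.0-fold lower number from compound 1 to compound 2 (0.02 log units; within the scatter), was flat, so no movement beyond the scatter is expected. Compound 3 is estimated at 7000 nM, with a likely range from 2500 nM to 20000 nM, meaning an expected step of a 1.1-fold lower number from compound 2 to compound 3 (0.06 log units; within the scatter).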

Compound 3, half-maximal inhibitory concentration: 7530 nM
The estimate for compound 3 lay 1.1-fold (0.03 log units) below the measured number; measured number inside the range.
By their numbers in this assay, from the lowest: compounds 3, 2 and 1 (each within the scatter of the next).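

Placing 4-aminophenyl on the carbonyl carbon gives a 1.1-fold lower number from compound 2 to compound 3 (0.03 log units; within the scatter) in this assay and, read as amino in place of fluoro on an aromatic carbon, a 1.1-fold lower number from compound 1 to compound 3 (0.04 log units; within the scatter) in the same assay. The position has now taken a group with a hydrogen-bond donor and fewer heavy atoms than 2,4-dimethoxyphenyl, and the number still stayed within the scatter, so the flat result extends to a third aryl group. No measurement available here explains why these exchanges leave the number unchanged.

Still open, as far as these compounds go, is whether any group on the carbonyl carbon can move the number beyond the scatter. A carboxylic acid on the aromatic ring, or a longer chain in place of that ring, would test this.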